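Series notes: compound 2 to compound 3

The compounds below may be only part of what the source reports. "The series", "measured", "known", "first", "only" and "open" are said of these compounds alone.

- compound 1 `Cc1cccc(-c2cc(-c3ccoc3)cc(-c3ccc(Cl)s3)n2)c1` gives 13700 nM in a functional assay on K562 cells (Homo sapiens) for cytotoxicity, read by ELISA, with a stated time of 4 days; on this read-out lower numbers stand for stronger inhibition and higher numbers for weaker inhibition
- compound 2 `Clc1cccc(-c2cc(-c3ccoc3)cc(-c3ccc(Cl)s3)n2)c1` gives 22100 nM in this assay

On these two numbers, compound 2 cannot be separated from compound 1. Within the data shown here, the one measured step is a 1.6-fold higher number from compound 1 to compound 2 (0.21 log units; within the scatter) and it covers only chloro in place of methyl on an aromatic carbon.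

The next compound is compound 3 `Clc1ccc(-c2cc(-c3ccoc3)cc(-c3ccccn3)n2)s1` and its change is pyridin-2-yl in place of 3-chlorophenyl on an aromatic carbon. Among the measured compounds shown here, no measured step covers this exchange, so the single step above bears on it only loosely and gives no direction. The expectation therefore starts from compound 2 at 22100 nM and assumes little movement in this assay on this evidence. The expected step is a 1.5-fold lower number from compound 2 to compound 3 (0.17 log units; within the scatter) and no firm direction is implied. The estimate for compound 3 is 15000 nM and its expected range runs from 5000 nM to 45000 nM on this read-out.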

Compound 3, half-maximal inhibitory concentration: 20000 nM
Compound 3: middle estimate off by 1.3-fold (0.12 log units), on the low side; measured number inside the range.
By their numbers in this assay, from the lowest: compounds 1, 3 and 2 (each within the scatter of the next).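

In this assay, the earlier pair varied only the small group on a phenyl ring, whereas this change replaces that ring with pyridin-2-yl, next to the ring nitrogen of the shared core, and gives a 1.1-fold lower number from compound 2 to compound 3 (0.04 log units; within the scatter). The exchange for 3-methylphenyl gives a 1.5-fold higher number from compound 1 to compound 3 (0.16 log units; within the scatter), so with a ring nitrogen entering and neither chloro nor methyl present, all three compounds remain inseparable at this position. No supporting data bear on why this exchange leaves the number unresolved from the others.

As far as these compounds go, the furan-3-yl and 5-chlorothiophen-2-yl groups are common to all three compounds, so their contribution remains open. From the compounds shown here alone, it is also open whether an amine or a carboxylic acid at this position would give a number separated from these three.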